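Notes on the amide-to-ether swap in the shared core

A few compounds are considered here, and "the series" means these few. Any claim that something is new, unique, unknown or untested is made for them only; others in the source may bear on it.

Compound 1 `CCc1cccc2c(OC)c(-c3occ(C)c3C(=O)NC)ccc12` is the reference point of the set. In a functional assay on A549 cells (Homo sapiens) for cytotoxicity, read by MTT assay, with a stated time of 72 h (a lower number here means that less compound is needed, a higher number that more compound is needed for the effect), compound 1 gives only a limit of the assay, > 10 ug/mL. Compound 2 `CCc1cccc2c(OC)c(-c3occ(C)c3C(=O)On3nnc4ccccc43)ccc12` carries a different group on the carbonyl carbon; in this assay compound 2 also gives only a limit, > 10 ug/mL. Compound 3 `CCOc1c(-c2occ(C)c2CO)ccc2c(CC)cccc12` likewise gives only a limit in this assay, > 10 ug/mL. For the measured compounds named here, the one step that joins two measured compounds, a step that the two limits leave unreadable from compound 1 to compound 2, is therefore of unreadable size, because the limit of > 10 ug/mL in this assay, at which 3 of the 3 values shown sit, holds for the whole set.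

Compound 4 `CCc1cccc2c(OC)c(-c3occ(C)c3COCC(F)(F)F)ccc12` differs from compound 1 by (2,2,2-trifluoroethoxy)methyl in place of methylcarbamoyl on an aromatic carbon. Going by the values given here, no measured step bears directly on this change; the only step at hand, a step that the two limits leave unreadable from compound 1 to compound 2, cannot be read, and every value shown is a limit rather than a number. Compound 1 stands at that limit, and the shown numbers give no direction for the change. The expectation for compound 4 in this assay is therefore again a value at or near the limit: the estimate is 15 ug/mL, with a range from 7 ug/mL to 40 ug/mL. The step that this estimate means, a step that the limit leaves unreadable from compound 1 to compound 4, is expected to be none beyond the scatter.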

Compound 4, concentration for half-maximal effect: > 10 ug/mL
Compound 4 was reported as a limit; the forecaster's own chance of this, stated with the estimate: 80%; the middle value does not contradict the limit.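

In this assay compound 4 gives > 10 ug/mL as a limit and not a number. For the compounds shown here, no step from compound 1 to compound 4 can be read, and the set offers no comparison: the limit of > 10 ug/mL in this assay, at which 4 of the 4 values shown sit. The compounds shown leave open whether any change on the shared core, including (2,2,2-trifluoroethoxy)methyl in place of methylcarbamoyl, moves the response in this assay off that limit.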